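Swapping a ring for a fluorobenzyl ether on the core

This account rests on a few compounds, and the source may have more. Where it says the series, first, only, none or still open, it means among the compounds named here.

Measured compounds:
- compound 1 `CC(C(=O)NCc1ccc(C(F)(F)F)cc1N1CCCC1)c1ccc(NS(C)(=O)=O)c(F)c1`: 2.3 nM
- compound 2 `CCCOc1cc(C(F)(F)F)ccc1CNC(=O)C(C)c1ccc(NS(C)(=O)=O)c(F)c1`: 2 nM
- compound 3 `CC(C)COc1cc(C(F)(F)F)ccc1CNC(=O)C(C)c1ccc(NS(C)(=O)=O)c(F)c1`: 0.8 nM

All three were tested in an assay on CHO cells for antagonist activity at transient receptor potential cation channel subfamily V member 1 (Homo sapiens), read by FLIPR; a higher number here means a weaker inhibitor, a lower number a stronger inhibitor. Compound 1 gives the highest of the three numbers; compound 2 sits within the scatter of it, while compound 3 lies a 2.9-fold lower number from compound 1 to compound 3 (0.46 log units; beyond the scatter). The steps that separate them are a 1.2-fold lower number from compound 1 to compound 2 (0.06 log units; within the scatter) and a 2.5-fold lower number from compound 2 to compound 3 (0.40 log units; beyond the scatter), so only the change to isobutoxy moved the number beyond the scatter, and only modestly.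

Compound 4 `CC(C(=O)NCc1ccc(C(F)(F)F)cc1OCc1ccc(F)cc1)c1ccc(NS(C)(=O)=O)c(F)c1` is the new compound. It differs from compound 1 by one change: (4-fluorobenzyl)oxy in place of pyrrolidin-1-yl on an aromatic carbon. The two measured steps from compound 1 bear on this, since both likewise put an oxygen-linked group in place of pyrrolidin-1-yl at the same position: a 1.2-fold lower number from compound 1 to compound 2 (0.06 log units; within the scatter) and a 2.9-fold lower number from compound 1 to compound 3 (0.46 log units; beyond the scatter). Both kept the number or lowered it slightly. Compound 4 is therefore expected to land near or a little under compound 1, with a step of about a 1.5-fold lower number from compound 1 to compound 4 (0.19 log units; within the scatter). The estimate for compound 4 in this assay is 1.5 nM, with a plausible range from 0.4 nM to 6 nM.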

Compound 4, inhibition constant: 0.5 nM
Compound 4: middle estimate off by 3.0-fold (0.48 log units), on the high side, within the range that was stated.
By their numbers in this assay, from the lowest: compounds 4 and 3 (each within the scatter of the next); then compounds 2 and 1 (each within the scatter of the next).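

Compound 4 shows that this aromatic carbon, meta to a trifluoromethyl group, can carry a group with a whole six-membered aromatic ring of carbon only, something the simple chains of compounds 2 and 3 could not show: in this assay the swap from pyrrolidin-1-yl to (4-fluorobenzyl)oxy gives a 4.6-fold lower number from compound 1 to compound 4 (0.66 log units; beyond the scatter) and is not penalised. The ring also separates compound 4 from the propoxy ether, with 4-fluorophenyl in place of ethyl giving a 4.0-fold lower number from compound 2 to compound 4 (0.60 log units; beyond the scatter) and so a real change, yet it does not separate compound 4 from the isobutoxy ether, where 4-fluorophenyl in place of isopropyl gives a 1.6-fold lower number from compound 3 to compound 4 (0.20 log units; within the scatter) and the branched chain and the ring cannot be told apart. Nothing measured here accounts for these steps.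

Whether the fluorine itself contributes would take a plain benzyloxy group on the same carbon to decide, and a 4-chlorobenzyloxy or pyridin-3-ylmethoxy group would show how much the ring can vary. Also open, as far as these compounds go, is how a longer chain, such as pentyloxy, would compare with the isobutoxy and the benzyl ethers.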